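From oxan-4-yl to 2-methoxyphenyl: an expected lipophilicity step

A few compounds are considered here, and "the series" means these few. Any claim that something is new, unique, unknown or untested is made for them only; others in the source may bear on it.

Measured so far:
Compound 1 `CCC/N=C1\S/C(=C\c2ccc(O)c(Cl)c2)C(=O)N1C1CCOCC1`: 3.7
Compound 2 `Cc1ccccc1N1C(=O)/C(=C/c2ccc(O)c(Cl)c2)S/C1=N\CCO`: 1.9

For the measured compounds named here, both compounds have been measured in a physicochemical assay for lipophilicity, read by HPLC, at pH 7.4; a higher number here means a more lipophilic compound, a lower number a more polar compound. Compound 1 gives 3.7, the higher of the two numbers. Compound 2 gives 1.9, and the gap between the two lies beyond the usual scatter of repeated measurements.

The next compound to be measured is compound 3 `CCC/N=C1\S/C(=C\c2ccc(O)c(Cl)c2)C(=O)N1c1ccccc1OC`. It has 2-methoxyphenyl in place of oxan-4-yl on an amide-type nitrogen in a ring, and the rest of compound 1 stays unchanged: 2-methoxyphenyl in place of oxan-4-yl on an amide-type nitrogen in a ring.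

Going by the values given here, no two measured compounds differ in just one place, so the data offer no direct precedent for this swap. Compound 2 differs from compound 1 in more than one place, and the value of compound 2, 1.9, cannot be divided among those differences. Judging from the structural change alone, a modest upward step in this assay is expected, slightly larger than the scatter. The estimated change is a number 0.50 log units higher from compound 1 to compound 3 (beyond the scatter). For compound 3 the estimate is 4.2, with an expected range of 3.7 to 4.7.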

Compound 3, distribution coefficient: 3.3
Compound 3: the middle estimate sits 0.90 log units above what was measured, and the stated range ends above it.
By their numbers in this assay, from the lowest: compound 2; then compound 3; then compound 1.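

In this assay, for the compounds shown here, the replacement of oxan-4-yl by 2-methoxyphenyl on the amide-type nitrogen gives the first direct reading of a change at this position: a number 0.40 log units lower from compound 1 to compound 3 (beyond the scatter) and is modest in size, though beyond the usual scatter. The swap turns a six-membered non-aromatic ring with 1 hetero atom into a six-membered aromatic ring of carbon only, and the incoming group has 8 heavy atoms against 6 while the counts of hydrogen-bond donors and acceptors stay the same, so in this pair the larger group carries the lower number. No measurement on hand accounts for the direction of this step.

This single pair cannot show how a plain phenyl, or a group carrying an amine or a carboxylic acid, would read on this nitrogen in this assay. It also leaves open whether the same swap would give a step of similar size and direction if the rest of compound 1 were changed, for instance with a longer chain in place of the one it carries.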